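This account rests on a few compounds, and the source may have more. Where it says the series, first, only, none or still open, it means among the compounds named here.

Measured so far:
- compound 1 `Cn1c(=O)c2[nH]c(Cc3ccco3)nc2n(Cc2ccco2)c1=O`: in an assay on HEK293 cells for displacement of a labelled ligand from adenosine receptor A2b (Homo sapiens) (a lower number here means a stronger inhibitor, a higher number a weaker inhibitor), compound 1 gives 316 nM
- compound 2 `CCSCCn1c(=O)c2[nH]c(Cc3cccs3)nc2n(Cc2ccco2)c1=O`: in this assay compound 2 gives 275 nM
- compound 3 `C#CCn1c(=O)c2[nH]c(Cc3cccs3)nc2n(Cc2ccco2)c1=O`: in this assay compound 3 gives 269 nM

Compound 3 holds the lowest number of the three in this assay, but the values of compound 2 and of compound 1 sit within the scatter of it, so no order among the three can be read from these numbers.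

The next member is compound 4 `C=CCn1c(=O)c2[nH]c(Cc3cccs3)nc2n(Cc2ccco2)c1=O`. It differs from compound 3 in one place: vinyl in place of ethynyl on a saturated chain carbon bound to an aromatic nitrogen. Cut one bond further out, the same difference reads propargyl to allyl.

Going by the values given here, only one measured step concerns the same position, the chain on the saturated carbon bound to the aromatic nitrogen: a 1.0-fold lower number from compound 2 to compound 3 (0.01 log units; within the scatter). That exchange, which swapped a (ethylsulfanyl)methyl group for an ethynyl group, left the number unchanged within the scatter. Among the compounds with values here, the unbranched vinyl group of compound 4 is a smaller move than that one, and no measured compound in the set points to a direction for it.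

Compound 4 is therefore expected to give 280 nM in this assay, within a range of 140 nM to 560 nM. The expected step is a 1.0-fold higher number from compound 3 to compound 4 (0.02 log units; within the scatter), that is none beyond the scatter, because the step of a 1.0-fold lower number from compound 2 to compound 3 (0.01 log units; within the scatter) at this chain was itself within the scatter.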

Compound 4, inhibition constant: 550 nM
Compound 4: the middle estimate sits 2.0-fold (0.29 log units) below what was measured; the measured number falls inside the stated range.
By their numbers in this assay, from the lowest: compounds 3, 2, 1 and 4 (each within the scatter of the next, the first and the last beyond it).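

In this assay the chain on the saturated carbon bound to the aromatic nitrogen now gives its first step beyond the scatter: a 2.0-fold higher number from compound 3 to compound 4 (0.31 log units; beyond the scatter). This modest step comes from exchanging ethynyl for vinyl, two groups of equal heavy-atom count that differ in a triple versus a double bond, so this place is not wholly indifferent to what it carries. The picture is not a clean order, however: a 2.0-fold higher number from compound 2 to compound 4 (0.30 log units; within the scatter) stays within the scatter, as does a 1.0-fold lower number from compound 2 to compound 3 (0.01 log units; within the scatter), and the larger exchange of (ethylsulfanyl)methyl gives no step beyond the scatter in either case; no data at hand account for the difference between ethynyl and vinyl.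

From the compounds shown here alone, whether a fully saturated propyl chain at this place would extend the step seen on going from ethynyl to vinyl remains open. Also open, going by these compounds, is whether a longer alkyl chain, or a chain ending in an amine or a carboxylic acid, would move the number beyond the scatter in either direction.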